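Compound 1 to compound 3: exchange on an aromatic oxygen

The source may hold more compounds than are shown below. What is called first, only, known or untested is meant among the compounds shown, and "the series" means these compounds.

Compound 1 `COC(=O)CNC(=O)CCC(=O)Oc1ccc(C[C@H]2C(=O)OC[C@@H]2Cc2ccc(OC)c(OC)c2)cc1OC`: 179000 nM
Compound 2 `COC(=O)[C@H](CC(C)C)NC(=O)CCC(=O)Oc1ccc(C[C@H]2C(=O)OC[C@@H]2Cc2ccc(OC)c(OC)c2)cc1OC`: 53200 nM

Within the data shown here, in an ADME assay on HeLa cells (Homo sapiens) for cytotoxicity, read by MTT assay (a lower number here means a stronger inhibitor, a higher number a weaker inhibitor), compound 1 holds the higher of the two numbers so far, and compound 2 is its nearest neighbour.

Compound 3 `COc1ccc(C[C@H]2COC(=O)[C@@H]2Cc2ccc(OCC(=O)N3CCCC3)c(OC)c2)cc1OC` is the next to be read. Its change from compound 1 lies on an oxygen on an aromatic ring: a group of 8 heavy atoms (6 carbon, 1 nitrogen, 1 oxygen; one five-membered non-aromatic ring with 1 hetero atom) in place of a group of 12 heavy atoms (7 carbon, 1 nitrogen, 4 oxygen; no ring), on an oxygen on an aromatic ring.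

Among the measured compounds shown here, only one measured step bears on this, and only indirectly. That step, a 3.4-fold lower number from compound 1 to compound 2 (0.53 log units; beyond the scatter), put isobutyl in place of hydrogen on a saturated chain carbon bound to an amide-type nitrogen and a carbonyl carbon, inside the group that leaves in compound 3. For the measured compounds named here, no measured step covers the exchange of the whole group, so the size of the modest step serves as the only guide. A step of similar modest size towards a lower number is expected, with wide uncertainty that includes no change beyond the scatter.

The expected step is a 2.0-fold lower number from compound 1 to compound 3 (0.30 log units; within the scatter). For compound 3 the estimated value is 90000 nM, with an expected range from 30000 nM to 250000 nM.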

Compound 3, half-maximal inhibitory concentration: >= 600000 nM
Compound 3 was reported as a limit (the forecaster's own chance of this, stated with the estimate: 15%); middle value at least 6.6-fold (0.82 log units) from the limit.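

In this assay, the exchange on an oxygen on an aromatic ring gives an at least 3.3-fold higher number from compound 1 to compound 3 (0.52 log units; beyond the scatter), while the earlier change inside the chain gave a 3.4-fold lower number from compound 1 to compound 2 (0.53 log units; beyond the scatter), so changes to the substituent on this oxygen can move the number either way. The earlier pair varied only one carbon within the chain, whereas this exchange replaces the whole group with ((pyrrolidin-1-yl)carbonyl)methyl and shows that the shorter, ring-bearing group gives a step beyond the scatter in the direction of a weaker inhibitor. Compound 3 gives >= 600000 nM, which is a limit of the assay and not a number, so the step has a lower bound and no measured size: the limit of >= 600000 nM in this assay, at which 1 of the 3 values shown sits.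

On these data alone, the exchange alters the ring and the chain together, so it remains open whether the step follows from the entering pyrrolidine ring or from the loss of the longer chain with its ester and amide. A morpholine amide, a primary amide or a free carboxylic acid on the same oxygen would help separate these two readings, and a compound reading below the limit would give the step a size.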